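The source may hold more compounds than are shown below. What is called first, only, known or untested is meant among the compounds shown, and "the series" means these compounds.

Measured so far in a physicochemical assay for solubility, at pH 6.8; a higher number here means a more soluble compound, a lower number a less soluble compound:
- compound 1 `COC(=O)CN1CC[C@H](NC(=O)c2cc3cc(Cl)ccc3[nH]2)[C@H](NC(=O)c2nc3c(s2)CN(C)CC3)C1`: 28 ug/mL
- compound 2 `CN1CCc2nc(C(=O)N[C@@H]3CN(CC(=O)O)CC[C@@H]3NC(=O)c3cc4cc(Cl)ccc4[nH]3)sc2C1`: 723 ug/mL
- compound 3 `CN1CCc2nc(C(=O)NC3CCN(C(=O)OC(C)(C)C)CC3NC(=O)c3cc4cc(Cl)ccc4[nH]3)sc2C1`: < 1 ug/mL (a limit)

Compound 3 reads < 1 ug/mL, a limit of the assay and not a number, so any number reported for compound 4 would lie higher.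

Compound 4 `CN1CCc2nc(C(=O)NC3CCN(S(C)(=O)=O)CC3NC(=O)c3cc4cc(Cl)ccc4[nH]3)sc2C1` differs from compound 3 in one place: it carries methylsulfonyl in place of tert-butoxycarbonyl on an amine nitrogen in a ring.

For the measured compounds named here, only one measured step is available as a guide. It is a 26-fold higher number from compound 1 to compound 2 (1.41 log units; beyond the scatter), and it shows that a single small edit moved the value a long way in this set. However, that step is hydrogen in place of methyl, a different change, so its size does not carry over and offers only loose support.

A modest upward step in this assay is therefore expected, estimated as an at least 3.0-fold higher number from compound 3 to compound 4 (0.47 log units; beyond the scatter). Compound 4 may still return only a limit.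

For compound 4 the estimated value is 3 ug/mL, with an expected range from 1 ug/mL to 15 ug/mL.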

Compound 4, solubility: 70 ug/mL
Beside the measured number, compound 4's estimate is 23-fold (1.37 log units) below it; measured number above the stated range.
By their numbers in this assay, from the lowest: compound 1; then compound 4; then compound 2. At a limit, below all of these: compound 3.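

In this assay, exchanging the group on the amine nitrogen in the ring gives a large change even though neither group carries a net charge: the result is an at least 70-fold higher number from compound 3 to compound 4 (1.84 log units; beyond the scatter). Compound 3 reads < 1 ug/mL, which is a limit of the assay and not a number. The earlier step altered only the end of a side chain on this nitrogen, from methyl to hydrogen on an oxygen, whereas this one replaces the whole group with one that has fewer heavy atoms and includes sulfur.

The compounds shown do not separate the effect of group size from that of the sulfur, a question that an acetyl group or a longer chain such as ethylsulfonyl on the same nitrogen could address. The true size of the step also stays open because compound 3 stands at a limit: the limit of < 1 ug/mL in this assay, at which 1 of the 4 values shown sits.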